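The compounds below may be only part of what the source reports. "The series", "measured", "known", "first", "only" and "open" are said of these compounds alone.

Measured so far in a functional assay on cells for agonist activity at G-protein coupled receptor 52 (Homo sapiens), read by AlphaScreen and cAMP accumulation, with a stated time of 30 min; a higher number here means a larger maximal response, a lower number a smaller maximal response:
- compound 1, `CCc1cc(-c2sc(Cc3cccc(C(F)(F)F)c3)nc2C)ccc1C(N)=O`: 84%
- compound 2, `Cc1nc(Cc2cccc(C(F)(F)F)c2)sc1-c1ccc(C(N)=O)cn1`: 70%
- compound 3, `COc1cccc(Cc2nc(C)c(-c3ccc(C(N)=O)c(C)c3)s2)c1`: 85%

Compound 3 gives 85% in this assay, and compound 1 gives 84%, a value within the usual scatter of it; the two cannot be ordered. Compound 2, at 70%, lies beyond the scatter below compound 3. Going by the values given here, no pair of these three differs in one place only, so no single-point step is available as a guide.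

Compound 4, `Cc1cc(-c2sc(Cc3cccc(F)c3)nc2C)ccc1C(N)=O`, is not yet measured. It differs from compound 3 by fluoro in place of methoxy on an aromatic carbon. On the evidence of these three compounds alone, no shift beyond the scatter is expected from this change; the step from compound 3 to compound 4 is estimated at a number 5 percentage points lower from compound 3 to compound 4 (within the scatter). Compound 4 is expected to give about 80% in this assay, with a likely range from 65% to 95%.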

Compound 4, largest response reached (Emax), in percent of the reference or control that the assay uses: 75%
For compound 4 the middle estimate is 5 percentage points above the measured one; the range from low to high includes it.
By their numbers in this assay, from the lowest: compounds 2, 4, 1 and 3 (each within the scatter of the next, the first and the last beyond it).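

In this assay, going by these compounds alone, the change from 3-methoxyphenyl to 3-fluorophenyl gives the first step that differs in one place, a number 10 percentage points lower from compound 3 to compound 4 (within the scatter) and so does not separate the two groups. On this evidence, the position on the aromatic ring meta to a large group accepts either methoxy or fluoro without a maximal response change beyond the scatter. This rests on one pair only.

From the compounds shown here alone, whether an amine, a carboxylic acid or a longer chain at this position would keep the response remains open. Nothing shown bears on the reason for this step.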